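Chain substituent at the shared core: cyclopropyl to tert-butyl

A few compounds are considered here, and "the series" means these few. Any claim that something is new, unique, unknown or untested is made for them only; others in the source may bear on it.

Compound 1 `Cc1nc2ccc(-n3ccc(OCc4ccc(F)cc4)cc3=O)cc2n1C` gives 77 nM in an assay on CHO cells for displacement of a labelled ligand from melanin-concentrating hormone receptor 1 (Homo sapiens), read by scintillation counting, with a stated time of 1 h; on this read-out lower numbers stand for stronger inhibition and higher numbers for weaker inhibition.
Compound 2 `Cn1c(C2CC2)nc2ccc(-n3ccc(OCc4ccc(F)cc4)cc3=O)cc21` gives 40 nM in this assay.
Compound 3 `Cn1c(CC2CC2)nc2ccc(-n3ccc(OCc4ccc(F)cc4)cc3=O)cc21` gives 90 nM in this assay.

Compound 3 carries the highest of the three numbers. Its distance to compound 1 is small, a 1.2-fold higher number from compound 1 to compound 3 (0.07 log units; within the scatter), and lies within the scatter; its distance to compound 2 is larger, a 2.3-fold higher number from compound 2 to compound 3 (0.35 log units; beyond the scatter), and lies beyond it. Compound 4 `Cn1c(CC(C)(C)C)nc2ccc(-n3ccc(OCc4ccc(F)cc4)cc3=O)cc21` differs from compound 3 in one place: tert-butyl in place of cyclopropyl on a saturated chain carbon bound to an aromatic carbon.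

Going by the values given here, two measured steps bear on this. The step of a 1.2-fold higher number from compound 1 to compound 3 (0.07 log units; within the scatter) shows that attaching cyclopropyl to the saturated chain carbon leaves the number essentially where it was. The step of a 2.3-fold higher number from compound 2 to compound 3 (0.35 log units; beyond the scatter) shows a modest rise when the group on the aromatic carbon is lengthened from cyclopropyl to cyclopropylmethyl. Among the compounds with values here, no measured pair covers tert-butyl or neopentyl on this position. Taken together, the steps suggest that changes at this chain carbon move the number little, with the only shift seen so far pointing towards higher numbers.

Compound 4 is therefore expected to sit close to compound 3, with a step of about a 1.2-fold higher number from compound 3 to compound 4 (0.09 log units; within the scatter) in this assay. The estimate for compound 4 is 110 nM, within a range from 45 nM to 270 nM.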

Compound 4, half-maximal inhibitory concentration: > 1000 nM
Compound 4: no number, only a limit; the forecaster's own chance of this, stated with the estimate: 2%; middle value at least 9.0-fold (0.95 log units) from the limit.
By their numbers in this assay, from the lowest: compounds 2, 1 and 3 (each within the scatter of the next, the first and the last beyond it). At a limit, above all of these: compound 4.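

In this assay compound 4 gives > 1000 nM as a limit of the assay and not a number. Swapping cyclopropyl for tert-butyl on a saturated chain carbon bound to an aromatic carbon gives an at least 11-fold higher number from compound 3 to compound 4 (1.04 log units; beyond the scatter), the first large step in the series, and it changes the reading of this position: the chain carbon had looked nearly indifferent to what it carries, with the earlier steps either within the scatter or modest. The neopentyl compound is also separated from the two other compounds, with an at least 25-fold higher number from compound 2 to compound 4 (1.39 log units; beyond the scatter) and an at least 12-fold higher number from compound 1 to compound 4 (1.11 log units; beyond the scatter), so the tolerance seen for methyl, cyclopropyl and cyclopropylmethyl on the aromatic carbon does not extend to neopentyl, although the change from cyclopropyl to tert-butyl goes only from 3 to 4 heavy atoms.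

On these data alone, how far compound 4 lies past its limit stays open, and with it the full size of these steps. Also open, as far as these compounds go, is whether the sharp rise belongs to tert-butyl alone or would also appear with isopropyl, a longer straight chain or an amine on the same saturated chain carbon.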